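The compounds below may be only part of what the source reports. "The series", "measured", "known", "first", "only" and "open" are said of these compounds alone.

Working notes on the series, read in a toxicity assay on EA.hy 926 cells (Homo sapiens) for cytotoxicity, read by MTT assay, with a stated time of 48 h; on this read-out higher numbers stand for weaker inhibition and lower numbers for stronger inhibition.

Compound 1 `COc1cc(/C=C/C2=CC(=O)CC(c3ccc(O)c(OC)c3)N2CCCO)ccc1O` returns only a limit of the assay in this assay, > 100000 nM. Compound 2 `COCCCN1C(/C=C/c2ccc(O)cc2)=CC(=O)CC1c1ccc(O)cc1` likewise returns only a limit in this assay, > 100000 nM. Among the measured compounds shown here, compound 3 `COCCNC(=C\C(=O)/C=C/c1ccc(O)cc1)/C=C/c1ccc(O)cc1` is the one member that gives a number in this assay, 45100 nM, so it stands as the only value among the three that is not a limit, the other two sitting at the limit of > 100000 nM in this assay, at which 2 of the 3 values shown sit. Nothing more can be read between compound 3 and compound 1 or compound 2 than that those two return a limit where compound 3 returns a number.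

Compound 4 `O=C(/C=C(/C=C/c1ccc(O)cc1)NCCCO)/C=C/c1ccc(O)cc1` has not yet been measured in this assay. Against compound 3 it differs by hydroxymethyl in place of methoxy on a saturated chain carbon, two bonds along the chain from an amine nitrogen. For the measured compounds named here, no step between two measured compounds touches this part of the chain, so there is no measured step to lean on. The change swaps a methoxy for a hydroxymethyl, two bonds along the chain from an amine nitrogen, on the core of compound 3. The expected step is a 1.1-fold higher number from compound 3 to compound 4 (0.04 log units; within the scatter), none beyond the usual scatter. Compound 4 is therefore expected to give about 50000 nM in this assay, within the range 20000 nM to 120000 nM.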

Compound 4, half-maximal inhibitory concentration: 57300 nM
Beside the measured number, compound 4's estimate is 1.1-fold (0.06 log units) below it; low and high end bracket the measured number.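

Among the compounds shown here, the first measured step at this part of the chain, in this assay, is small (a 1.3-fold higher number from compound 3 to compound 4 (0.10 log units; within the scatter)), so hydroxymethyl in place of methoxy on a saturated chain carbon, two bonds along the chain from an amine nitrogen, stays within the usual scatter. The hydrogen-bond donor that hydroxymethyl carries and methoxy lacks therefore leaves no readable difference between this pair, and (3-hydroxypropyl)amino and (2-methoxyethyl)amino can be treated as equivalent on the core of compound 3 in this read-out. Nothing at hand bears on why the two values lie so close.

The compounds shown leave open whether a longer chain, an amine or a carboxylic acid at the end of this chain would read the same in this assay. Also open, as far as these compounds go, is whether the same exchange reads alike on any other core, as neither compound 1 nor compound 2 forms a one-place pair with compound 3 or compound 4.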